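Bombesin receptor subtype-3 agonists: 2-cyanophenyl in place of isobutyl

A few compounds are considered here, and "the series" means these few. Any claim that something is new, unique, unknown or untested is made for them only; others in the source may bear on it.

Measured compounds, all in an in vitro functional assay on cells for agonist activity at Bombesin receptor subtype-3 (Mus musculus), read by luminescence and calcium flux; a lower number here means that less compound is needed, a higher number that more compound is needed for the effect:
Compound 1 `COc1cccc(Cc2cnc(CCc3ccc(-c4ccccc4C(=O)O)cc3)[nH]2)c1` gives 79 nM.
Compound 2 `O=C(O)c1ccccc1-c1ccc(CCc2ncc(Cc3ccccc3F)[nH]2)cc1` gives 9.5 nM.
Compound 3 `CC(C)CCc1cnc(CCc2ccc(-c3ccccc3C(=O)O)cc2)[nH]1` gives 10 nM.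

Compound 3 stands second highest of the three numbers. Its nearest neighbour is compound 2, the step being a 1.1-fold higher number from compound 2 to compound 3 (0.02 log units; within the scatter); the furthest is compound 1, with a 7.9-fold lower number from compound 1 to compound 3 (0.90 log units; beyond the scatter). The two aromatic groups on the saturated chain carbon thus behave differently: 3-methoxyphenyl sits well above isobutyl, 2-fluorophenyl sits level with it.

Compound 4 `N#Cc1ccccc1Cc1cnc(CCc2ccc(-c3ccccc3C(=O)O)cc2)[nH]1` differs from compound 3 in one place: 2-cyanophenyl in place of isobutyl on a saturated chain carbon bound to an aromatic carbon. Within the data shown here, two measured steps bear on this. a 1.1-fold higher number from compound 2 to compound 3 (0.02 log units; within the scatter) shows one six-membered aromatic ring at this position giving a number within scatter of isobutyl; a 7.9-fold lower number from compound 1 to compound 3 (0.90 log units; beyond the scatter) shows another giving a modestly higher number. Among the measured compounds shown here, no measured step contains a nitrile. The entering 2-cyanophenyl, named like 2-fluorophenyl rather than 3-methoxyphenyl, is expected to give a number close to that of compound 3, any step within or barely beyond the scatter in either direction.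

The step from compound 3 is expected to be a 1.4-fold higher number from compound 3 to compound 4 (0.15 log units; within the scatter). Compound 4 is estimated at 14 nM, between 5 nM and 45 nM.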

Compound 4, half-maximal effective concentration: 642 nM
Compound 4: middle estimate off by 46-fold (1.66 log units), on the low side; measured number above the stated range.
By their numbers in this assay, from the lowest: compounds 2 and 3 (each within the scatter of the next); then compound 1; then compound 4.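

In this assay, a six-membered aromatic ring on the saturated chain carbon bound to an aromatic carbon is not in itself level with isobutyl: 2-cyanophenyl in place of isobutyl gives a large rise in the number (a 64-fold higher number from compound 3 to compound 4 (1.81 log units; beyond the scatter)). The substituent on that ring decides much of the outcome, since cyano in place of fluoro alone gives a similarly large rise (a 68-fold higher number from compound 2 to compound 4 (1.83 log units; beyond the scatter)). 2-Cyanophenyl also stands modestly above 3-methoxyphenyl (an 8.1-fold higher number from compound 1 to compound 4 (0.91 log units; beyond the scatter)), so the three aromatic groups span a wide range at this position, and no measurement in hand accounts for that spread.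

The compounds shown leave open whether the rise follows the nitrile wherever it sits on the ring, as 3-cyanophenyl would test. They also leave open whether 2-chlorophenyl or 2-methoxyphenyl would stay level with 2-fluorophenyl or move toward 2-cyanophenyl.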